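The compounds below may be only part of what the source reports. "The series", "measured", "known", "first", "only" and "open" are said of these compounds alone.

Working notes on a small set built on the shared core of compound 1 `NC(=O)/C=C/c1ccncc1-c1ccc2ccccc2c1`. In a functional assay on A549 cells (Homo sapiens) for inhibition, read by sulforhodamine B assay, with a stated time of 72 h (a higher number here means a weaker inhibitor of growth, a lower number a stronger inhibitor of growth), compound 1 gives > 10000 nM, which is a limit of the assay and not a number. For the measured compounds named here, compound 2 `CCOC(=O)/C=C/c1ccncc1-c1ccc2c(ccn2C)c1` is the only member with a numeric result: in this assay compound 2 gives 1720 nM. Compound 3 `O=C(/C=C/c1ccncc1-c1ccc2cc[nH]c2c1)N1CCOCC1` is again at a limit; in this assay compound 3 gives > 10000 nM. On the numbers shown, compound 1 therefore stands at the limit of > 10000 nM in this assay, at which 2 of the 3 values shown sit, and between compound 1 and compound 3 two limits permit no ordering.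

Compound 4 `O=C(/C=C/c1ccncc1-c1ccc2ccccc2c1)N1CCOCC1` has not yet been measured. It differs from compound 1 in one place: morpholin-4-yl in place of amino on a carbonyl carbon. Going by the values given here, no pair of measured compounds differs by this change alone, so no measured step for it is known; compound 3 carries the same morpholin-4-yl group on its carbonyl but a different aromatic partner.

Given that compound 1 and compound 3 both sit at the limit, the step is expected to be none beyond the scatter, a number no higher from compound 1 to compound 4 (the limit leaves the size open). Compound 4 is accordingly estimated at 10000 nM, in a range from 3000 nM to 30000 nM, with a real chance that the assay once more reports only a limit.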

Compound 4, concentration for 50% growth inhibition: 8410 nM
For compound 4 the middle estimate is 1.2-fold (0.08 log units) above the measured one, within the range that was stated.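

In this assay, for the compounds shown here, morpholin-4-yl in place of amino on a carbonyl carbon gives an at least 1.1-fold lower number from compound 1 to compound 4 (0.07 log units; that floor lies within the scatter), and this is the first step that can be read on the core of compound 1. Only the floor of that step is known, and it does not establish a real gain; what the result does show is that a ring-bearing group at this carbonyl carbon, with no hydrogen-bond donor, still leaves compound 4 with a numeric reading on this core. That reading sits close to the limit of the assay, which still holds part of the set: the limit of > 10000 nM in this assay, at which 2 of the 4 values shown sit.

The true size of the step stays open, as compound 1 carries only a limit, and the numbers give no cause for the difference between the amino and morpholin-4-yl groups. Also open, from the compounds shown here alone, is what a dimethylamino or piperazin-1-yl group, or the hydroxyl of a carboxylic acid, would give on this same carbonyl carbon, and whether any such group would bring the core of compound 1 clearly away from the limit.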